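The compounds below may be only part of what the source reports. "The series", "measured", "known", "first", "only" and "open" are said of these compounds alone.

Measured compounds:

- compound 1 `CC(C)(C)CCN1C(=O)C(C2=NS(=O)(=O)c3cc(NS(C)(=O)=O)ccc3N2)=C(O)C2CCCCCCC21`: in an ADME assay on Huh-7 cells (Homo sapiens) for cytotoxicity, with a stated time of 72 h (on this read-out lower numbers stand for higher toxicity in this test and higher numbers for lower toxicity in this test), compound 1 is recorded as "not determined" (no result reported)
- compound 2 `CS(=O)(=O)Nc1ccc2c(c1)S(=O)(=O)N=C(C1=C(O)C3CCCCC3N(Cc3ccc(F)cc3)C1=O)N2`: compound 2 gives > 33000 nM, a limit of the assay
- compound 3 `CS(=O)(=O)Nc1ccc2c(c1)S(=O)(=O)N=C(C1=C(O)C3CCCC3N(Cc3ccc(Cl)cc3)C1=O)N2`: compound 3 gives > 10000 nM, also a limit of the assay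

Nothing measured in this series reaches a numbered value. Compound 2 stands at the limit of this assay, as does compound 3, while compound 1 has no result at all. The two limits differ only in where the assay was cut off: the limit of > 10000 nM in this assay, at which 1 of the 3 values shown sits; (the limit of > 33000 nM in this assay, at which 1 of the 3 values shown sits). For the measured compounds named here, no step between measured compounds can be counted, so no trend in cytotoxicity is established for the shared core.

The step to follow is from compound 2 to compound 4 `CC(C)(C)CCN1C(=O)C(C2=NS(=O)(=O)c3cc(NS(C)(=O)=O)ccc3N2)=C(O)C2CCCCC21`, which is to be measured in this assay. The change is neopentyl in place of 4-fluorophenyl on a saturated chain carbon bound to an amide-type nitrogen in a ring. The rest of the core of compound 2 is kept.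

Given that compound 2 sits at a limit with > 33000 nM and nothing in the series shows measurable toxicity, the expectation is that compound 4 will again return a limit rather than a number, and the step of a number no higher from compound 2 to compound 4 (the limit leaves the size open) is estimated to be none beyond the scatter. The estimate for compound 4 in this assay is 33000 nM, within a range of 10000 nM to 100000 nM.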

Compound 4, half-maximal cytotoxic concentration: > 33000 nM
Compound 4: a limit, no number; the forecaster's own chance of this, stated with the estimate: 80%; the middle value lies on the limit itself.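

In this assay compound 4 gives > 33000 nM, a limit of the assay. Compound 2 stands at the same limit, and the step from compound 2 to compound 4 cannot be read: the limit of > 33000 nM in this assay, at which 2 of the 4 values shown sit.

The compounds shown leave open whether neopentyl or 4-fluorophenyl in this place changes cytotoxicity, and at what concentration either compound becomes toxic to these cells.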